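A few compounds are considered here, and "the series" means these few. Any claim that something is new, unique, unknown or untested is made for them only; others in the source may bear on it.

Three compounds share one core and differ only in the aryl group on the thiourea nitrogen. Compound 1 `CNC(=O)c1ccc(Oc2cccc(NC(=S)Nc3ccc(F)c(F)c3)c2)nc1` carries a 3,4-difluorophenyl group and gives 23100 nM in a functional assay on PC-3 cells (Homo sapiens) for antiproliferative activity, read by MTT assay; a higher number here means a weaker inhibitor, a lower number a stronger inhibitor. Compound 2 `CNC(=O)c1ccc(Oc2cccc(NC(=S)Nc3ccc(OC)cc3)c2)nc1` carries a 4-methoxyphenyl group; in this assay compound 2 reaches only the limit > 100000 nM, a boundary of the measurement rather than a number. Compound 3 `CNC(=O)c1ccc(Oc2cccc(NC(=S)Nc3cccc(C(F)(F)F)c3)c2)nc1` carries a 3-(trifluoromethyl)phenyl group and gives 15400 nM in this assay, the lowest of the two numbers, with compound 1 nearest to it.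

The steps among them differ in size. Swapping 3,4-difluorophenyl for 4-methoxyphenyl gives an at least 4.3-fold higher number from compound 1 to compound 2 (0.63 log units; beyond the scatter), swapping it for 3-(trifluoromethyl)phenyl gives a 1.5-fold lower number from compound 1 to compound 3 (0.18 log units; within the scatter), and going from 4-methoxyphenyl to 3-(trifluoromethyl)phenyl gives an at least 6.4-fold lower number from compound 2 to compound 3 (0.81 log units; beyond the scatter).

Compound 4 `CNC(=O)c1ccc(Oc2cccc(NC(=S)Nc3ccc(Cl)c(C(F)(F)F)c3)c2)nc1` differs from compound 3 by chloro in place of hydrogen on an aromatic carbon. Among the compounds with values here, the closest precedent is the pair of compound 1 and compound 3, two fluorine-bearing aryl groups that sit within the scatter of each other; no measured pair shows the effect of adding a single chloro group. The expected step in this assay is therefore small, a 1.4-fold lower number from compound 3 to compound 4 (0.15 log units; within the scatter), and compound 4 is estimated at 11000 nM, between 4000 nM and 30000 nM.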

Compound 4, half-maximal inhibitory concentration: 1980 nM
Compound 4: the middle estimate sits 5.6-fold (0.74 log units) above what was measured, outside the stated range (below it).
By their numbers in this assay, from the lowest: compound 4; then compounds 3 and 1 (each within the scatter of the next). At a limit, above all of these: compound 2.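

Chloro in place of hydrogen, ortho to a trifluoromethyl group and para to a large group, gives a 7.8-fold lower number from compound 3 to compound 4 (0.89 log units; beyond the scatter) in this assay. Within the data shown here, the earlier steps each exchanged one whole aryl group for another, and the only step between two fluorine-bearing groups stayed small, a 1.5-fold lower number from compound 1 to compound 3 (0.18 log units; within the scatter), so they gave no sign that this position could respond so clearly. Here a change of just 1 heavy atom on an aromatic carbon moves the number beyond the scatter, showing that this part of the aryl group is not indifferent to substitution, although nothing among the data shown explains why the step has this size.

The compounds shown leave open whether this step belongs to chloro itself or depends on the trifluoromethyl group already on the ring, as the step is seen only in this one pair. They also leave open how other groups at this same place would behave, such as bromo, a methyl group, an amine or a carboxylic acid.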